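From 4-cyanophenyl to 4-fluorophenyl: expectations for compound 4

This account rests on a few compounds, and the source may have more. Where it says the series, first, only, none or still open, it means among the compounds named here.

Three compounds have numbers in a functional assay on HT-29 cells (Homo sapiens) for inhibition, with a stated time of 72 h; on this read-out higher numbers stand for weaker inhibition and lower numbers for stronger inhibition: compound 1 `COc1ccc(S(=O)(=O)N2CCc3cccc(-c4ccc(F)cc4)c32)cc1` gives 85.5 nM, compound 2 `COc1ccc(S(=O)(=O)n2ccc3cccc(-c4ccc(C#N)cc4)c32)cc1` gives 164 nM and compound 3 `COc1ccc(S(=O)(=O)N2CCc3cccc(-c4cccnc4)c32)cc1` gives 76.3 nM. Compound 2 stands on the weaker side of compound 3, beyond the scatter, while compound 2 and compound 1 lie within the scatter of each other.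

The next structure is compound 4 `COc1ccc(S(=O)(=O)n2ccc3cccc(-c4ccc(F)cc4)c32)cc1`, which keeps the core of compound 2 and carries fluoro in place of cyano on an aromatic carbon. Within the data shown here, no measured pair shows this exchange directly. Among the measured compounds shown here, compound 1 and compound 3 share a core that differs from the one in compound 2 and compound 4, so the evidence is indirect. For the measured compounds named here, the one measured step that swaps the aryl group, pyridin-3-yl in place of 4-fluorophenyl, is a 1.1-fold lower number from compound 1 to compound 3 (0.05 log units; within the scatter), and it stays within the scatter. On that basis, only a small change is expected, with a slight lean towards a lower number. The estimated step is a 1.4-fold lower number from compound 2 to compound 4 (0.15 log units; within the scatter), which is not expected to exceed the scatter. In this assay the estimated value for compound 4 is 115 nM, with an expected range from 55 nM to 240 nM.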

Compound 4, half-maximal inhibitory concentration: 196 nM
The estimate for compound 4 lay 1.7-fold (0.23 log units) below the measured number, and the stated range covers the measured number.
By their numbers in this assay, from the lowest: compounds 3, 1, 2 and 4 (each within the scatter of the next, the first and the last beyond it).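

In this assay, the exchange of fluoro for cyano on the six-membered aromatic ring of carbon only, para to a large group, can now be read directly on the core of compound 2: it gives a 1.2-fold higher number from compound 2 to compound 4 (0.08 log units; within the scatter) and stays within the scatter. Among these compounds, until now, the only aryl change available was on the other core (a 1.1-fold lower number from compound 1 to compound 3 (0.05 log units; within the scatter)), so the series now has one exchange of this kind on each core, and neither step goes beyond the scatter. Nothing at hand explains why the two substituents read alike at this position.

With 4-fluorophenyl held fixed, compound 1 gives 85.5 nM and compound 4 gives 196 nM, but this single pair cannot show whether the difference between the two cores holds for other aryl groups. On the core of compound 4, only cyano and fluoro are shown at this position, so the effect of an amine, a carboxylic acid or a longer chain there remains open.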